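From 2-phenylethenyl to thiophen-3-yl on a shared core

The compounds below may be only part of what the source reports. "The series", "measured", "known", "first", "only" and "open" are said of these compounds alone.

In a functional assay on A549 cells (Homo sapiens) for inhibition, read by MTT assay, with a stated time of 48 h (on this read-out higher numbers stand for weaker inhibition and lower numbers for stronger inhibition), compound 1 `CS(=O)(=O)c1ccc(-c2nc3ccccn3c2Sc2ccccc2)cc1` gives 23200 nM, and compound 2 `C(=C/c1nc2ccccn2c1Sc1ccccc1)\c1ccccc1` gives 16300 nM. These two values lie within the usual scatter of each other, so compound 2 stands level with compound 1, and both sit in the same weak range. Compound 3 `c1ccc(Sc2c(-c3ccsc3)nc3ccccn23)cc1`, not yet measured, carries thiophen-3-yl in place of 2-phenylethenyl on an aromatic carbon of the shared core (thiophen-3-yl in place of 2-phenylethenyl on an aromatic carbon). For the measured compounds named here, compound 1 and compound 2 carry different groups on that carbon yet read alike, which is the only evidence available for this change. No step beyond the scatter is therefore expected in this assay, and no clear direction can be argued. The expected step is small: a 1.2-fold higher number from compound 2 to compound 3 (0.07 log units; within the scatter). Compound 3 is estimated at 19000 nM, with an expected range from 8000 nM to 45000 nM.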

Compound 3, half-maximal inhibitory concentration: 72900 nM
The estimate for compound 3 lay 3.8-fold (0.58 log units) below the measured number, and the stated range ends below it.
By their numbers in this assay, from the lowest: compounds 2 and 1 (each within the scatter of the next); then compound 3.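

In this assay, putting thiophen-3-yl in place of 2-phenylethenyl gives a 4.5-fold higher number from compound 2 to compound 3 (0.65 log units; beyond the scatter), so the change is not neutral on this read-out. This shows that the aromatic carbon next to the ring nitrogen responds to the group it carries, which the level readings of compound 1 and compound 2 had not shown. The entering group has 5 heavy atoms against 8 and 1 hydrogen-bond acceptor against 0, but no measurement here ties the step to either difference.

The compounds shown leave open whether the loss follows from the thiophen-3-yl ring itself or from the removal of 2-phenylethenyl. They also leave open how an amine or a carboxylic acid on this carbon would read against compound 2 and compound 3.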